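Ring Size at the Thiocarbonyl: Expecting Compound 4

The source may report more compounds than this note shows. Statements on the series, on what has been measured and on what is new or still open speak of the compounds shown alone.

Four compounds share a thiosemicarbazide-like arrangement around a methylpyridine core and were, or are to be, tested in a functional assay on MCF7 cells (Homo sapiens) for cytotoxicity, read by MTT assay, with a stated time of 72 h; a lower number here means a stronger inhibitor, a higher number a weaker inhibitor. Compound 1 `Cc1cccc(/C(N)=N/NC(=S)N2CCCCC2)n1` gives 74000 nM. Compound 2 `Cc1cccc(/C(N)=N/NC(=S)N2CCCC2)n1` gives 61800 nM; the change from compound 1 to compound 2 is pyrrolidin-1-yl in place of piperidin-1-yl on a thiocarbonyl carbon and the step is a 1.2-fold lower number from compound 1 to compound 2 (0.08 log units; within the scatter). Compound 3 `Cc1ccnc(/C(N)=N/NC(=S)N2CCCCC2)c1` gives 18800 nM, the lowest number of the three; how its core differs from that of compound 1 is not broken down here. Compound 4 `Cc1ccnc(/C(N)=N/NC(=S)N2CCCC2)c1` is not yet measured; it differs from compound 3 by pyrrolidin-1-yl in place of piperidin-1-yl on a thiocarbonyl carbon, the same change seen between compound 1 and compound 2. The expected step is a 1.2-fold lower number from compound 3 to compound 4 (0.07 log units; within the scatter), because the earlier step of a 1.2-fold lower number from compound 1 to compound 2 (0.08 log units; within the scatter) was small. Compound 4 is therefore estimated at 16000 nM, within 7000 nM to 35000 nM.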

Compound 4, half-maximal inhibitory concentration: 1200 nM
Estimate against measurement, compound 4: 13-fold (1.12 log units) above, and the stated range ends above it.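

In this assay, putting pyrrolidin-1-yl in place of piperidin-1-yl gives a 16-fold lower number from compound 3 to compound 4 (1.19 log units; beyond the scatter), and this step does not match the one seen on the other core: the same change on two cores in this assay, a 1.2-fold lower number (0.08 log units; within the scatter) from compound 1 to compound 2 and a 16-fold lower number (1.19 log units; beyond the scatter) from compound 3 to compound 4, 13-fold (1.12 log units) apart, beyond the scatter of two such steps

So, for these two pairs, the effect of this change depends on the core that carries it, and a small step on one core did not predict the step on the other. The pairs do not show which difference between the cores is responsible, or how the change would behave on any further core.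

From the compounds shown here alone, it remains open how an open-chain dimethylamino or diethylamino group on the thiocarbonyl carbon would compare with the rings on each core. Whether such a group would also respond differently on the two cores is equally unresolved.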